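This account rests on a few compounds, and the source may have more. Where it says the series, first, only, none or still open, it means among the compounds named here.

Among the compounds with values here, compound 1 `CC(=O)c1ccc(-c2sc(N)c(C(=O)c3ccccc3)c2-c2cccc(C(F)(F)F)c2)cc1` gives 25.6% in an assay on CHO-K1 cells for displacement of a labelled ligand from adenosine receptor A1 (Homo sapiens), tested at 10 uM (a lower number here means less inhibition, a higher number more inhibition at the concentration tested (going by the name of the read-out)), and stands lowest of the three numbers measured so far. Compound 2 `CCOC(=O)c1c(N)sc(-c2ccc(C(C)=O)cc2)c1-c1cccc(C(F)(F)F)c1` gives 64.6% in this assay, and compound 3 `CCOC(=O)c1c(N)sc(-c2ccc(-c3ccncc3)cc2)c1-c1cccc(C(F)(F)F)c1` gives 91%. The two measured steps are a number 39 percentage points higher from compound 1 to compound 2 (beyond the scatter) and a number 26.4 percentage points higher from compound 2 to compound 3 (beyond the scatter); the first puts ethoxy in place of phenyl on a carbonyl carbon, the second pyridin-4-yl in place of acetyl on an aromatic carbon. Compound 4 `Nc1sc(Cl)c(-c2cccc(C(F)(F)F)c2)c1C(=O)c1ccccc1` differs from compound 1 as follows: chloro in place of 4-acetylphenyl on an aromatic carbon. Within the data shown here, neither measured step touches this position, so no step bears directly on it. With the benzoyl group of compound 1 kept and the 4-acetylphenyl group removed, a downward step a number 10.6 percentage points lower from compound 1 to compound 4 (beyond the scatter) is expected. Compound 4 is estimated at 15%, within 0% to 40%.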

Compound 4, a percentage reported as inhibition, at one concentration (the size of the read-out at that concentration, not a potency): 87.1%
Estimate against measurement, compound 4: 72.1 percentage points below; measured number outside the range, above it.
By their numbers in this assay, from the lowest: compound 1; then compound 2; then compounds 4 and 3 (each within the scatter of the next).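

In this assay the aromatic carbon next to the ring sulfur proves highly sensitive to its substituent: with the benzoyl group kept, chloro in place of 4-acetylphenyl gives a step of a number 61.5 percentage points higher from compound 1 to compound 4 (beyond the scatter) in this series. The 4-acetylphenyl group is therefore not required for inhibition at this position. Nothing measured here accounts for the rise.

Open, from the compounds shown here alone, is whether the gain is specific to chloro, or whether bromo, methyl or a bare ring hydrogen would match it. Also open, going by these compounds, is whether chloro behaves the same with ethoxy in place of phenyl on the carbonyl carbon.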